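The source may hold more compounds than are shown below. What is called first, only, known or untested is meant among the compounds shown, and "the series" means these compounds.

Measured so far in an assay on K562 cells for displacement of a labelled ligand from Equilibrative nucleoside transporter 1 (Homo sapiens), read by flow cytometry, with a stated time of 45 min; on this read-out higher numbers stand for weaker inhibition and lower numbers for stronger inhibition:
compound 1 `CNc1nc(SCc2ccc([N+](=O)[O-])cc2)c2ncn([C@@H]3O[C@H](CO)[C@@H](O)[C@H]3O)c2n1` gives 24 nM;
compound 2 `CCCNc1nc(SCc2ccc([N+](=O)[O-])cc2)c2ncn([C@@H]3O[C@H](CO)[C@@H](O)[C@H]3O)c2n1` gives 193 nM;
compound 3 `CCCCCNc1nc(SCc2ccc([N+](=O)[O-])cc2)c2ncn([C@@H]3O[C@H](CO)[C@@H](O)[C@H]3O)c2n1` gives 357 nM.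

Compound 3 stands highest of the three numbers; against compound 2 the gap is a 1.8-fold higher number from compound 2 to compound 3 (0.27 log units; within the scatter), against compound 1 it is a 15-fold higher number from compound 1 to compound 3 (1.17 log units; beyond the scatter).

Compound 4 `O=[N+]([O-])c1ccc(CSc2nc(Cl)nc3c2ncn3[C@@H]2O[C@H](CO)[C@@H](O)[C@H]2O)cc1` differs from compound 3 by chloro in place of pentylamino on an aromatic carbon. Within the data shown here, no measured step covers this kind of change. The measured steps, an 8.0-fold higher number from compound 1 to compound 2 (0.91 log units; beyond the scatter) and a 15-fold higher number from compound 1 to compound 3 (1.17 log units; beyond the scatter), only show that lengthening the chain on the amino group raised the number in this assay; compound 4 has no such chain. A step downward from compound 3 to compound 4 is therefore expected, but its size is uncertain, so the range is set wide. For compound 4 in this assay the estimate is 120 nM (range 20 nM to 700 nM), a step of a 3.0-fold lower number from compound 3 to compound 4 (0.47 log units; beyond the scatter).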

Compound 4, inhibition constant: 11 nM
Estimate against measurement, compound 4: 11-fold (1.04 log units) above; measured number outside the range, below it.
By their numbers in this assay, from the lowest: compound 4; then compound 1; then compounds 2 and 3 (each within the scatter of the next).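

In this assay the group on this aromatic carbon need not be an alkylamino group for a low number: chloro gives a 32-fold lower number from compound 3 to compound 4 (1.51 log units; beyond the scatter) and an 18-fold lower number from compound 2 to compound 4 (1.24 log units; beyond the scatter) and, against methylamino, still a 2.2-fold lower number from compound 1 to compound 4 (0.34 log units; beyond the scatter) on the same shared core. The earlier compounds shown here compared only chain lengths on the amino nitrogen, whereas chloro, with no hydrogen-bond donor or acceptor, gives compound 4 the lowest number of the four.

On these data alone, whether an unsubstituted amino group, a methoxy group or bromo at this carbon would match chloro stays open. Nothing at hand accounts for the size of these steps.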